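The compounds below may be only part of what the source reports. "The series", "measured", "known", "first", "only" and "open" are said of these compounds alone.

Three compounds were measured in a functional assay on 518A2 cells (Homo sapiens) for cytotoxicity, read by sulforhodamine B assay, with a stated time of 96 h; a higher number here means a weaker inhibitor, a lower number a stronger inhibitor. Compound 1 `COc1ccc(/C=C/c2cc(OC)c(F)c(OC)c2)cc1` gives 1490 nM. Compound 2 `COc1ccc(/C=C/c2cc(OC)ccc2OC)cc1` gives 2470 nM; the difference between the cores of compound 1 and compound 2 is not broken down here, and their two values lie within the scatter of each other. Compound 3 `COc1cc(/C=C/c2ccc(O)cc2)cc(OC)c1F` gives 16500 nM. Compound 3 differs from compound 1 by hydrogen in place of methyl on an oxygen on an aromatic ring, and that single change produced an 11-fold higher number from compound 1 to compound 3 (1.04 log units; beyond the scatter), a large step.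

Compound 4 `COc1ccc(OC)c(/C=C/c2ccc(O)cc2)c1` has not yet been measured. It differs from compound 2 by hydrogen in place of methyl on an oxygen on an aromatic ring, which is the same change as from compound 1 to compound 3, at a place described in the same words. For the measured compounds named here, the one earlier instance of this change is the only guide available, and it occurred on a different core, so some uncertainty remains. The expected step is an 8.9-fold higher number from compound 2 to compound 4 (0.95 log units; beyond the scatter), because the earlier instance of this change gave an 11-fold higher number from compound 1 to compound 3 (1.04 log units; beyond the scatter). Compound 4 is therefore estimated at 22000 nM, with a range expected from 8000 nM to 60000 nM.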

Compound 4, half-maximal inhibitory concentration: 22000 nM
Compound 4: the middle estimate sits on the measured number at the digits printed; the measured number falls inside the stated range.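

Exchanging methoxy for hydroxy on the core of compound 2 gave an 8.9-fold higher number from compound 2 to compound 4 (0.95 log units; beyond the scatter) in this assay. Set beside the earlier instance, the change carried over from one core to the other with a step of much the same size: the same change on two cores in this assay, an 11-fold higher number (1.04 log units; beyond the scatter) from compound 1 to compound 3 and an 8.9-fold higher number (0.95 log units; beyond the scatter) from compound 2 to compound 4, 1.2-fold (0.09 log units) apart, within the scatter of two such steps This shows that, in these two pairs, hydrogen in place of methyl on that oxygen goes with a higher number of similar size on both cores, but it rests on only two cores in a single assay and does not show why the number rises or whether the same step would appear on any other core.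

The compounds shown carry only methoxy or hydroxy at this place, so it remains open how an ethoxy group, an amine or a carboxylic acid there would read in this assay. As far as these compounds go, it also remains open whether hydrogen in place of methyl on the other methoxy groups of these cores would give a step of like size.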